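This account rests on a few compounds, and the source may have more. Where it says the series, first, only, none or still open, it means among the compounds named here.

Compound 1 `CC(C)C(c1ccc(-c2ccc3cccc(F)c3c2)[nH]c1=O)N1CCN/C1=N\C#N`: 0.632 h
Compound 2 `CC(C)C(c1nnc[nH]1)c1ccc(-c2ccc3cccc(F)c3c2)[nH]c1=O`: 0.905 h
Compound 3 `CC(C)C(Cc1noc(=O)[nH]1)c1ccc(-c2ccc3cccc(F)c3c2)[nH]c1=O`: > 3 h (a limit, not a number)

All three compounds were tested in an ADME assay on microsomes from liver (Homo sapiens) for metabolic stability; on this read-out lower numbers stand for a shorter-lived compound and higher numbers for a longer-lived compound. Compound 3 gives > 3 h, which is a limit of the assay and not a number. Compound 4 `Cc1c[nH]c(C(c2ccc(-c3ccc4cccc(F)c4c3)[nH]c2=O)C(C)C)n1` carries 4-methyl-1H-imidazol-2-yl at the same place: a group of 6 heavy atoms (4 carbon, 2 nitrogen; one five-membered aromatic ring with 2 hetero atoms) in place of a group of 7 heavy atoms (3 carbon, 2 nitrogen, 2 oxygen; one five-membered aromatic ring with 3 hetero atoms), on a saturated chain carbon bound to an aromatic carbon and a saturated chain carbon. Three measured swaps at this place bear on the change. Reaching the group of compound 3 gave an at least 4.7-fold higher number from compound 1 to compound 3 (0.67 log units; beyond the scatter) and an at least 3.3-fold higher number from compound 2 to compound 3 (0.52 log units; beyond the scatter), while the remaining swap gave a 1.4-fold higher number from compound 1 to compound 2 (0.16 log units; within the scatter). Leaving that group is therefore expected to shorten the half-life, bringing compound 4 back towards compound 2 at 0.905 h. The expected step is an at least 3.3-fold lower number from compound 3 to compound 4 (0.52 log units; beyond the scatter). The estimate for compound 4 is 0.9 h, within an expected range of 0.4 h to 2.2 h.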

Compound 4, half-life: 0.09 h
For compound 4 the middle estimate is 10-fold (1.00 log units) above the measured one, outside the stated range (below it).
By their numbers in this assay, from the lowest: compound 4; then compounds 1 and 2 (each within the scatter of the next). At a limit, above all of these: compound 3.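

In this assay, compound 4 with 4-methyl-1H-imidazol-2-yl has the shortest half-life of the set, so aromatic five-membered rings are not interchangeable at this place (a 10-fold lower number from compound 2 to compound 4 (1.00 log units; beyond the scatter); a 7.0-fold lower number from compound 1 to compound 4 (0.85 log units; beyond the scatter)). Compound 3 gives > 3 h as a limit and not a number. The largest step (an at least 33-fold lower number from compound 3 to compound 4 (1.52 log units; beyond the scatter)) therefore gives only the smallest possible gap: the limit of > 3 h in this assay, at which 1 of the 4 values shown sits.

As far as these compounds go, whether the methyl group or the change in ring atoms drives the drop stays open, and the same ring without its methyl would separate the two. From the compounds shown here alone, how a carboxylic acid would behave at this place is also open.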